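The compounds below may be only part of what the source reports. "The series", "measured", "known", "first", "only" and "open" are said of these compounds alone.

Compound 1 `c1ccc(Oc2ccc3c(NCCCNCc4ccco4)ccnc3c2)cc1`: 15200 nM
Compound 2 `COc1ccccc1Oc1ccc2c(NCCCNCc3ccco3)ccnc2c1`: 6500 nM
Compound 3 `Clc1ccc(Oc2ccc3c(NCCCNCc4ccco4)ccnc3c2)cc1`: not yet measured

Among the compounds with values here, in an ADME assay on HepG2 cells (Homo sapiens) for cytotoxicity, read by luminescence, CellTiter-Glo and ATP content, with a stated time of 72 h (a lower number here means that less compound is needed, a higher number that more compound is needed for the effect), compound 2 gives 6500 nM, the lower of the two numbers so far. Compound 3 has 4-chlorophenyl in place of 2-methoxyphenyl on an oxygen on an aromatic ring. Within the data shown here, one measured step bears on this change, a 2.3-fold lower number from compound 1 to compound 2 (0.37 log units; beyond the scatter), where methoxy replaced hydrogen on an aromatic carbon. Among the measured compounds shown here, that single modest step sets the scale, but no measured step tests chlorine, so a similarly small change is expected, with no firm direction and probably nothing beyond the scatter. The expected step is a 1.2-fold higher number from compound 2 to compound 3 (0.09 log units; within the scatter). For compound 3 the estimate is 8000 nM, within a range of 3000 nM to 18000 nM.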

Compound 3, half-maximal effective concentration: 7800 nM
Compound 3: middle estimate off by 1.0-fold (0.01 log units), on the high side; the measured number falls inside the stated range.
By their numbers in this assay, from the lowest: compounds 2, 3 and 1 (each within the scatter of the next, the first and the last beyond it).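

In this assay the swap on the oxygen gives a 1.2-fold higher number from compound 2 to compound 3 (0.08 log units; within the scatter) and so does not separate 4-chlorophenyl from 2-methoxyphenyl. Chloro in place of hydrogen on an aromatic carbon gives a 1.9-fold lower number from compound 1 to compound 3 (0.29 log units; within the scatter) and also stays inside the usual scatter, so among these changes only adding methoxy reaches beyond it. Nothing available explains why these groups read so alike. Still open, from the compounds shown here alone, is whether an amine or a carboxylic acid on this aromatic ring would shift the number beyond the scatter. A longer chain in place of the phenyl group is equally untested by these compounds.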